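The compounds below may be only part of what the source reports. "The series", "measured", "known", "first", "only" and "open" are said of these compounds alone.

Compound 1 `O=c1[nH]c2ccc(Br)cc2nc1/C=C/c1ccc(Br)cc1` gives 0.0407 ug/mL in a functional assay on SF-268 cells (Homo sapiens) for inhibition, read by sulforhodamine B assay, with a stated time of 72 h; a lower number here means a stronger inhibitor, a higher number a weaker inhibitor. Compound 2 `O=c1[nH]c2ccc(Br)cc2nc1/C=C/c1ccc(O)cc1` gives 0.0228 ug/mL, and compound 3 `Cc1ccc(/C=C/c2nc3cc(Br)ccc3[nH]c2=O)cc1` gives 0.0168 ug/mL, the lowest number of the three, reached by a 2.4-fold lower number from compound 1 to compound 3 (0.38 log units; beyond the scatter) and by a 1.4-fold lower number from compound 2 to compound 3 (0.13 log units; within the scatter). Compound 4 `COc1ccc(/C=C/c2nc3cc(Br)ccc3[nH]c2=O)cc1` carries methoxy in place of methyl on an aromatic carbon. Going by the values given here, no measured pair shows this exact exchange, so the bearing steps are the neighbouring changes at the same carbon: a 1.8-fold lower number from compound 1 to compound 2 (0.25 log units; within the scatter), a 2.4-fold lower number from compound 1 to compound 3 (0.38 log units; beyond the scatter) and a 1.4-fold lower number from compound 2 to compound 3 (0.13 log units; within the scatter). All three were small, so for compound 4 no step beyond the scatter is expected in this assay, in either direction. Compound 4 is therefore expected at 0.02 ug/mL, with a range of 0.008 ug/mL to 0.05 ug/mL. For compound 4 this estimate means a 1.2-fold higher number from compound 3 to compound 4 (0.08 log units; within the scatter).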

Compound 4, half-maximal inhibitory concentration: 0.0002 ug/mL
For compound 4 the middle estimate is 100-fold (2.00 log units) above the measured one; the measured number lies below the stated range.
By their numbers in this assay, from the lowest: compound 4; then compounds 3, 2 and 1 (each within the scatter of the next, the first and the last beyond it).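

In this assay this carbon, para to a large group, proves far more sensitive than bromo, hydroxy and methyl suggested, since methoxy in place of methyl gives (an 84-fold lower number from compound 3 to compound 4 (1.92 log units; beyond the scatter)). Adding methyl to the oxygen of the hydroxy group (a 110-fold lower number from compound 2 to compound 4 (2.06 log units; beyond the scatter)) and replacing bromo with methoxy (a 200-fold lower number from compound 1 to compound 4 (2.31 log units; beyond the scatter)) are also large steps, so neither the oxygen alone, as in compound 2, nor the methyl alone, as in compound 3, reaches the number of compound 4. Nothing measured here accounts for the jump. From the compounds shown here alone, whether ethoxy, a longer alkoxy chain or an amine at this carbon holds the gain remains open.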